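Adding a chloro to the phenyl of compound 2

The compounds below may be only part of what the source reports. "The series", "measured", "known", "first", "only" and "open" are said of these compounds alone.

Compound 2 `O=C1c2ccccc2C(=O)N1CCOC(=S)N(C(=O)c1ccc(Cl)c(Cl)c1)c1ccccc1` is examined in an ADME assay on MT4 cells (Homo sapiens) for cytotoxicity, read by MTT assay (a lower number here means that less compound is tolerated, a higher number that more compound is tolerated), where compound 2 gives 52000 nM. Compound 3 `O=C1c2ccccc2C(=O)N1CCOC(=S)N(C(=O)c1ccc(Cl)c([N+](=O)[O-])c1)c1ccccc1` gives 51000 nM in this assay, and the step of a 1.0-fold lower number from compound 2 to compound 3 (0.01 log units; within the scatter) leaves the two within the scatter of each other. Compound 1 `CCCCCOc1ccc(C(=O)N(C(=S)OCCN2C(=O)c3ccccc3C2=O)c2ccc(F)cc2)cc1` reaches only a limit of this assay, at > 100000 nM, so that the limit of > 100000 nM in this assay, at which 1 of the 3 values shown sits, gives no number for it. Compound 4 `O=C1c2ccccc2C(=O)N1CCOC(=S)N(C(=O)c1ccc(Cl)c(Cl)c1)c1ccc(Cl)cc1` differs from compound 2 by chloro in place of hydrogen on an aromatic carbon, phenyl to 4-chlorophenyl. For the measured compounds named here, no measured step touches this ring, and the only measured step, on the other ring, stayed within the scatter, so no step beyond the scatter is expected in this assay. Compound 4 is therefore estimated at 50000 nM, between 20000 nM and 100000 nM, an expected step of a 1.0-fold lower number from compound 2 to compound 4 (0.02 log units; within the scatter).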

Compound 4, half-maximal cytotoxic concentration: 35000 nM
For compound 4 the middle estimate is 1.4-fold (0.15 log units) above the measured one; measured number inside the range.
By their numbers in this assay, from the lowest: compounds 4, 3 and 2 (each within the scatter of the next). At a limit, above all of these: compound 1.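

In this assay, chloro in place of hydrogen on an aromatic carbon, para to a large group, gives a 1.5-fold lower number from compound 2 to compound 4 (0.17 log units; within the scatter). For the compounds shown here, this is the only measured change on this ring, and like the step on the other ring, it stays within the scatter, so phenyl to 4-chlorophenyl cannot be told apart from no change here. Nothing shown bears on why this position behaves so. Still open, from the compounds shown here alone, is whether an amine or a carboxylic acid in place of this chloro would bring a step beyond the scatter.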